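The compounds below may be only part of what the source reports. "The series", "measured", "known", "first", "only" and "open" are said of these compounds alone.

Compound 1, `COc1cc(-c2cc(/C=C/C(=O)c3ccc(N)cc3)[nH]n2)cc(OC)c1OC`, stands highest of the two numbers recorded in a functional assay on LOX IMVI cells (Homo sapiens) for cytotoxicity, read by sulforhodamine B assay, with a stated time of 48 h, tested at 0.01 uM (on this read-out lower numbers stand for a stronger effect and higher numbers for a weaker effect at the one concentration tested), where compound 1 gives 98%. Its nearest neighbour is compound 2, `COc1cc(-c2cc(/C=C/C(=O)c3ccc(Cl)c(Cl)c3)[nH]n2)cc(OC)c1OC`, which in this assay gives 96%; the step of a number 2 percentage points lower from compound 1 to compound 2 (within the scatter) is within the scatter. Compound 3, `COc1ccc(-c2cc(/C=C/C(=O)c3ccc(N)cc3)[nH]n2)cc1OC`, differs from compound 1 by hydrogen in place of methoxy on an aromatic carbon. Among the measured compounds shown here, no measured step concerns this change: the only one available replaces the group on the carbonyl carbon and stayed within the scatter. Compound 3 is therefore expected to give 97%, between 86% and 104%, a step of a number 1 percentage points lower from compound 1 to compound 3 (within the scatter) expected to stay within the scatter.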

Compound 3, a percentage reported as activity, at one concentration (the size of the read-out at that concentration, not a potency): 100%
Compound 3: middle estimate off by 3 percentage points, on the low side; the measured number falls inside the stated range.
By their numbers in this assay, from the lowest: compounds 2, 1 and 3 (each within the scatter of the next).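

Hydrogen in place of the methoxy group on this aromatic carbon gives a number 2 percentage points higher from compound 1 to compound 3 (within the scatter) in this assay and so adds a second change, now on the aromatic ring rather than on the carbonyl carbon, that leaves no readable difference at this one concentration. This methoxy group can therefore be lost without a visible change here, though that holds only for this pair. Nothing available bears on the reason for this result.

Going by these compounds, what a hydroxyl group or an amine on this carbon would do remains open. So does whether this change would show at a higher concentration, where the effect may be larger.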